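The compounds below may be only part of what the source reports. "The series", "measured", "known", "first", "only" and "open" are said of these compounds alone.

Measured in a functional assay on NCI-H460 cells (Homo sapiens) for positive allosteric modulation, read by MTT assay, with stated times of 2 h and 72 h, tested at 3 uM; a higher number here means a weaker inhibitor, a lower number a stronger inhibitor:
Compound 1 `CCCc1ccc(C(=O)Nc2ccccc2-c2nnn(-c3cccc(OC)c3)n2)cc1` gives 173 nM
Compound 2 `COc1cccc(-n2nnc(-c3ccccc3NC(=O)c3ccc(N)cc3)n2)c1` gives 212 nM
Compound 3 `COc1cccc(-n2nnc(-c3ccccc3NC(=O)c3ccc(NC(C)=O)cc3)n2)c1` gives 554 nM

Compound 3 has the highest number of the three, so it is the weakest inhibitor shown: a 2.6-fold higher number from compound 2 to compound 3 (0.42 log units; beyond the scatter) and a 3.2-fold higher number from compound 1 to compound 3 (0.51 log units; beyond the scatter) both lie beyond the scatter. Compound 4 `COc1cccc(-n2nnc(-c3ccccc3NC(=O)c3ccc(N=[N+]=[N-])cc3)n2)c1` differs from compound 3 in one place: azido in place of acetamido on an aromatic carbon.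

For the measured compounds named here, no measured step swaps acetamido for azido, so the bearing steps are indirect. Removing acetyl from the nitrogen, a 2.6-fold higher number from compound 2 to compound 3 (0.42 log units; beyond the scatter) read backwards, gave a modest gain, and propyl against acetamido, a 3.2-fold higher number from compound 1 to compound 3 (0.51 log units; beyond the scatter), a somewhat larger one. The azido group is expected to behave more like those smaller groups, so compound 4 is expected to show a 1.7-fold lower number from compound 3 to compound 4 (0.24 log units; within the scatter) in this assay. The estimate for compound 4 is 320 nM, expected to fall between 150 nM and 700 nM.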

Compound 4, half-maximal inhibitory concentration: 455 nM
Beside the measured number, compound 4's estimate is 1.4-fold (0.15 log units) below it, and the stated range covers the measured number.
By their numbers in this assay, from the lowest: compounds 1 and 2 (each within the scatter of the next); then compounds 4 and 3 (each within the scatter of the next).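

In this assay, azido in place of acetamido at this position, para to a large group, gives a 1.2-fold lower number from compound 3 to compound 4 (0.09 log units; within the scatter), so the assay does not separate these two groups. Azido also differs from the other two groups, with a 2.1-fold higher number from compound 2 to compound 4 (0.33 log units; beyond the scatter) and a 2.6-fold higher number from compound 1 to compound 4 (0.42 log units; beyond the scatter), which shows that a higher number here does not require an acetyl group. Nothing available explains these steps. Still open, from the compounds shown here alone, is whether a carboxylic acid or a longer chain such as butyl at this position would group with compound 1 and compound 2 or with compound 3 and compound 4.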